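A Larger Group on the Carbonyl Carbon

The source may hold more compounds than are shown below. What is called first, only, known or untested is meant among the compounds shown, and "the series" means these compounds.

In an ADME assay on Caco-2 cells (Homo sapiens) for permeability, in the apical to basolateral direction, at pH 7.4 (a lower number here means that the compound crosses the layer more slowly, a higher number that the compound crosses the layer faster), compound 2 `Cc1csc(C(=O)N[C@H]2CN(S(=O)(=O)c3ccccc3)C[C@@H]2C(=O)N[C@H]2CCCNC2)n1` gives 0.18 10^-6 cm/s. Among the compounds with values here, that is the higher of the two numbers so far. Compound 1 `Cc1ccc2[nH]c(C(=O)N[C@H]3CN(S(=O)(=O)c4ccccc4)C[C@@H]3C(=O)N[C@@H]3CCCNC3)cc2c1` gives 0.04 10^-6 cm/s. The gap between these two numbers lies beyond the scatter. Compound 3 `O=C(N[C@H]1CN(S(=O)(=O)c2ccccc2)C[C@@H]1C(=O)N[C@H]1CCCNC1)c1nnc(-c2ccc(F)cc2)s1` replaces the 4-methyl-1,3-thiazol-2-yl group on a carbonyl carbon: a group of 12 heavy atoms (8 carbon, 2 nitrogen, 1 fluorine, 1 sulfur; one five-membered aromatic ring with 3 hetero atoms, one six-membered aromatic ring of carbon only) in place of a group of 6 heavy atoms (4 carbon, 1 nitrogen, 1 sulfur; one five-membered aromatic ring with 2 hetero atoms), on a carbonyl carbon. Within the data shown here, no measured pair differs in one place only, so the sole guide is compound 1, which also has a larger group there and gives 0.04 10^-6 cm/s. The expected change is a modest fall, close to the edge of the scatter: a 2.3-fold lower number from compound 2 to compound 3 (0.35 log units; beyond the scatter). For compound 3 the estimate is 0.08 10^-6 cm/s, with a range from 0.02 10^-6 cm/s to 0.3 10^-6 cm/s.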

Compound 3, apparent permeability: < 0.03 10^-6 cm/s
Compound 3 ended at the assay's limit; the forecaster's own chance of this, stated with the estimate: 20%; at least 2.6-fold (0.42 log units) between middle value and limit.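

Within the data shown here, on the carbonyl carbon, this is the first change in one place only that can be read: in this assay, the larger group brings an at least 6.0-fold lower number from compound 2 to compound 3 (0.77 log units; beyond the scatter). So at this position, the larger group goes with a fall beyond the scatter. The full size of the fall stays unknown because compound 3 gives a limit and not a number: the limit of < 0.03 10^-6 cm/s in this assay, at which 1 of the 3 values shown sits.

The compounds shown do not separate the effect of the five-membered aromatic ring with 3 hetero atoms from that of the six-membered aromatic ring of carbon only. Going by these compounds, how a short chain ending in an amine or a carboxylic acid would read at this position also stays open.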